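Carboxyphenyl Exchange in a Thallium-Flux Modulator Series

The source may hold more compounds than are shown below. What is called first, only, known or untested is meant among the compounds shown, and "the series" means these compounds.

Measured compounds:
compound 1 `Cc1c(OCCCCOc2cccc(C(=O)O)c2)ccc(C(=O)CC(C)C)c1C` — 18.3%
compound 2 `Cc1c(OCCCCOc2ccc(F)c(C(=O)O)c2)ccc(C(=O)CC(C)C)c1C` — 13.8%

In an assay on HEK293 cells for positive allosteric modulation of metabotropic glutamate receptor 3 (Rattus norvegicus), read by thallium flux, with a stated time of 2.5 min (a higher number here means a larger maximal response, a lower number a smaller maximal response), compound 2 gives 13.8%, the lowest of the two numbers shown; its nearest neighbour, compound 1, gives 18.3%, a gap within the scatter. Among the compounds with values here, the only measured step, a number 4.5 percentage points lower from compound 1 to compound 2 (within the scatter), concerns a fluoro exchange, not the carboxyphenyl change itself. Compound 3 `Cc1c(OCCCCOc2ccccc2C(=O)O)ccc(C(=O)CC(C)C)c1C` differs from compound 2 by 2-carboxyphenyl in place of 3-carboxy-4-fluorophenyl on an oxygen on a saturated carbon. Within the data shown here, no measured step bears on this change, so no shift beyond the scatter is expected. Compound 3 is expected to give 15%, between 5% and 30%. The estimated step is a number 1.2 percentage points higher from compound 2 to compound 3 (within the scatter).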

Compound 3, largest response reached (reported as percent of maximum), in percent of the reference or control that the assay uses: 30.7%
Beside the measured number, compound 3's estimate is 15.7 percentage points below it; measured number above the stated range.
By their numbers in this assay, from the lowest: compounds 2 and 1 (each within the scatter of the next); then compound 3.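

In this assay, 2-carboxyphenyl on an oxygen on a saturated carbon is the first exchange shown to go beyond the scatter, with a number 12.4 percentage points higher from compound 1 to compound 3 (beyond the scatter) when it replaces 3-carboxyphenyl and a number 16.9 percentage points higher from compound 2 to compound 3 (beyond the scatter) when it replaces 3-carboxy-4-fluorophenyl. Among these three compounds, the place of the carboxylic acid on the ring therefore counts for more than the fluoro exchange, whose step lies within the scatter. On these data alone, whether an amide or a tetrazole in place of the carboxylic acid would keep this higher response remains open. No measurement shown bears on why the response rises.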